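Two Fluorophenyl Isomers in a Histamine Agonist Series

The source may report more compounds than this note shows. Statements on the series, on what has been measured and on what is new or still open speak of the compounds shown alone.

Measured so far:
compound 1, `Cc1nc(N)sc1CCCN/C(N)=N/C(=O)NC(C)c1cccc(F)c1`: 26.3 nM
compound 2, `CCCCCCNC(=O)/N=C(\N)NCCCc1sc(N)nc1C`: 15.9 nM

The assay used is a functional assay on Right cardiac atrium for agonist activity at histamine H2 receptor (Cavia porcellus), with a stated time of 30 min, in the presence of a further agent that is not named here; a higher number here means that more compound is needed for the effect, a lower number that less compound is needed. In this assay compound 1 gives 26.3 nM, the higher of the two numbers recorded so far. Compound 2 gives 15.9 nM, and the gap between compound 2 and compound 1 lies within the usual scatter, so the two cannot be told apart on these data. For the measured compounds named here, no pair of measured compounds differs in a single place, so no measured step exists to lean on.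

Compound 3, `Cc1nc(N)sc1CCCN/C(N)=N/C(=O)NC(C)c1ccc(F)cc1`, is the next compound to be measured. It is built from the same atoms as compound 1, joined differently: 4-fluorophenyl in place of 3-fluorophenyl on a saturated chain carbon bound to an amide-type nitrogen and a saturated chain carbon

Going by the values given here, no measured step of this kind is available. The expectation for compound 3 rests only on compound 1, which gives 26.3 nM, and on the modest nature of the change. The step expected from compound 1 to compound 3 is a 1.1-fold lower number from compound 1 to compound 3 (0.02 log units; within the scatter), that is, no change beyond the scatter in either direction. Compound 3 is therefore estimated at 25 nM, with a likely range from 8 nM to 80 nM.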

Compound 3, half-maximal effective concentration: 23.4 nM
Compound 3: the middle estimate sits 1.1-fold (0.03 log units) above what was measured, and the stated range covers the measured number.
By their numbers in this assay, from the lowest: compounds 2, 3 and 1 (each within the scatter of the next).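

In this assay, placing 4-fluorophenyl in place of 3-fluorophenyl on the saturated chain carbon bound to an amide-type nitrogen and a saturated chain carbon gives the first single-place step available in this set, a 1.1-fold lower number from compound 1 to compound 3 (0.05 log units; within the scatter), and that step lies within the scatter. This exchange of one fluorophenyl isomer for the other leaves the heavy-atom count, the ring type and the donor and acceptor counts of the group unchanged, and on these data it does not separate the two compounds. The comparison of compound 1 with compound 2 could not show this, as those two do not differ in a single place, and no measurement here offers an explanation for the outcome.

Going by these compounds, it remains open whether unsubstituted phenyl, 2-fluorophenyl or 4-chlorophenyl at this same place would also stay within the scatter of compound 1. A single step also cannot say how far this place tolerates larger changes, such as a carboxylic acid or an amine on the phenyl ring.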